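The compounds below may be only part of what the source reports. "The series", "measured", "known", "first", "only" and "open" are said of these compounds alone.

Compound 3 `NC(=O)c1c(NC(=O)c2ccccc2Cl)sc2c1CCN(C(=S)Nc1ccccc1I)C2` is the strongest of the three measured compounds in a functional assay on MKN-74 cells (Homo sapiens) for antiproliferative activity, with a stated time of 24 h (a lower number here means a stronger inhibitor, a higher number a weaker inhibitor), where it gives 2630 nM. Compound 1 `NC(=O)c1c(NC(=O)c2ccccc2Cl)sc2c1CCNC2` gives 28700 nM in this assay, and compound 2 `NC(=O)c1c(NC(=O)c2ccccc2Cl)sc2c1CCN(Cc1ccc([N+](=O)[O-])cc1)C2` gives 31500 nM. The step of an 11-fold lower number from compound 1 to compound 3 (1.04 log units; beyond the scatter) and the step of a 12-fold lower number from compound 2 to compound 3 (1.08 log units; beyond the scatter) are both large, whereas the step of a 1.1-fold higher number from compound 1 to compound 2 (0.04 log units; within the scatter) is not distinguishable from noise.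

Compound 4 `NC(=O)c1c(NC(=O)c2ccccc2Cl)sc2c1CCN(C(=S)Nc1c(Cl)cccc1Cl)C2` keeps everything that sets compound 3 apart and changes only the aromatic ring on the thiourea: 2,6-dichlorophenyl in place of 2-iodophenyl on an amide-type nitrogen. None of the three measured steps bears directly on this position; each of them alters the substituent on the ring amine nitrogen, and the two large steps, from compound 1 to compound 3 and from compound 2 to compound 3, arise from adding the whole thiourea-linked aryl group rather than from swapping one halogenated phenyl for another. The data therefore give no measured guide to the size of an aryl-for-aryl exchange on the thiourea nitrogen, and the expectation for compound 4 is a step of a 1.0-fold lower number from compound 3 to compound 4 (0.00 log units; within the scatter) that stays within the scatter. Compound 4 is accordingly expected to give about 2600 nM in this assay, with a plausible range from 900 nM to 7500 nM.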

Compound 4, half-maximal inhibitory concentration: 4020 nM
For compound 4 the middle estimate is 1.5-fold (0.19 log units) below the measured one; the range from low to high includes it.
By their numbers in this assay, from the lowest: compounds 3 and 4 (each within the scatter of the next); then compounds 1 and 2 (each within the scatter of the next).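

Among the compounds shown here, at the amide-type nitrogen, this is the first exchange of one aryl group for another, and in this assay it gives a 1.5-fold higher number from compound 3 to compound 4 (0.18 log units; within the scatter) and so does not separate 2,6-dichlorophenyl from 2-iodophenyl. The advantage over the compounds lacking this thiocarbonyl-linked aryl group also survives the exchange, with a 7.8-fold lower number from compound 2 to compound 4 (0.89 log units; beyond the scatter) and a 7.1-fold lower number from compound 1 to compound 4 (0.85 log units; beyond the scatter) both beyond the scatter, which shows that it does not depend on 2-iodophenyl alone. No accompanying measurement is available to account for these results.

Both aryl groups shown carry halogen, so it remains open whether an unsubstituted phenyl, a methoxyphenyl or a carboxyphenyl on this nitrogen would stay within the scatter of compound 3 and compound 4 in this assay. For the compounds shown here, the compounds also leave open how much the thiocarbonyl itself contributes, as no analogue with a plain carbonyl in its place appears among them, and whether an alkyl group such as cyclohexyl could take the place of the aryl ring.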